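Cyclopropyl for isopropyl: a step from compound 2

The source may hold more compounds than are shown below. What is called first, only, known or untested is meant among the compounds shown, and "the series" means these compounds.

Three compounds of the shared core have been run in a functional assay for inhibition, with Homo sapiens as the target; a higher number here means a weaker inhibitor, a lower number a stronger inhibitor. Compound 1, `CCCc1nc(C)n2c(O)nncc12`, returns only a limit of the assay, > 48000 nM. Compound 2, `CCCc1nc(C)c2c(C(C)C)nnc(O)n12`, likewise returns only a limit, > 48000 nM. Compound 3, `Cc1ncc2cnnc(S)n12`, also reaches only a limit, > 48000 nM. Going by the values given here, no step between measured compounds is available because of the limit of > 48000 nM in this assay, at which 3 of the 3 values shown sit. Compound 2 therefore stands at the same limit as every other value shown, and nothing separates it from compound 1 or compound 3 on these numbers.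

Compound 4, `CCCc1nc(C)c2c(C3CC3)nnc(O)n12`, is the next member. It differs from compound 2 by cyclopropyl in place of isopropyl on an aromatic carbon. Among the compounds with values here, with all three values at the limit and no measured step to lean on, no direction can be drawn for this change; the step that the limit leaves unreadable from compound 2 to compound 4 is expected to be flat, with no shift beyond the scatter. Compound 4 is expected to give 60000 nM in this assay, within 20000 nM to 200000 nM, and most probably to be reported again only as a limit.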

Compound 4, half-maximal inhibitory concentration: > 48000 nM
Compound 4: no number, only a limit; the forecaster's own chance of this, stated with the estimate: 80%; the middle value lies beyond the limit too.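

No step can be read between compound 2 and compound 4, because both values are limits: the limit of > 48000 nM in this assay, at which 4 of the 4 values shown sit. The compounds shown leave open how cyclopropyl and isopropyl compare at this place, and whether any compound of the shared core gives a value short of the limit.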